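A trifluoromethyl group added to compound 3

This account rests on a few compounds, and the source may have more. Where it says the series, first, only, none or still open, it means among the compounds named here.

Compound 1 `c1ccc(-c2nn(-c3ccccc3)cc2-c2nc3ccccc3[nH]2)cc1` – 2710 nM
Compound 2 `COc1ccc2[nH]c(-c3cn(-c4ccccc4)nc3-c3ccccc3)nc2c1` – 1230 nM
Compound 3 `Fc1ccc(-c2nn(-c3ccccc3)cc2-c2nc3ccccc3[nH]2)cc1` – 1510 nM

In a functional assay on A549 cells (Homo sapiens) for antiproliferative activity, read by MTT assay, with a stated time of 48 h (on this read-out higher numbers stand for weaker inhibition and lower numbers for stronger inhibition), compound 3 stands at 1510 nM and lies within the scatter of both compound 2 and compound 1. Compound 4 `Fc1ccc(-c2nn(-c3ccccc3)cc2-c2nc3cc(C(F)(F)F)ccc3[nH]2)cc1` differs from it in one place, with trifluoromethyl in place of hydrogen on an aromatic carbon. That carbon belongs to a six-membered aromatic ring of carbon only, part of a fused or bridged system of two rings.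

Within the data shown here, no measured compound carries trifluoromethyl, so no step speaks to this group directly. The nearest guide is the methoxy change on that same ring system, which gave a 2.2-fold lower number from compound 1 to compound 2 (0.34 log units; beyond the scatter) and counts as modest. The fluoro change, made on another ring, gave a 1.8-fold lower number from compound 1 to compound 3 (0.25 log units; within the scatter) and stays within the scatter. Only the methoxy step therefore offers firm support for a lower number, and it comes from a different group. A small shift towards a lower number is expected in this assay and may not clear the scatter. The estimated step is a 1.6-fold lower number from compound 3 to compound 4 (0.20 log units; within the scatter) and would be no larger than the methoxy step. Compound 4 is estimated at 950 nM with an expected range (350 nM to 2500 nM).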

Compound 4, half-maximal inhibitory concentration: 2340 nM
Compound 4: the middle estimate sits 2.5-fold (0.39 log units) below what was measured; the range from low to high includes it.
By their numbers in this assay, from the lowest: compounds 2, 3, 4 and 1 (each within the scatter of the next, the first and the last beyond it).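

In this assay, trifluoromethyl in place of hydrogen on an aromatic carbon of the six-membered aromatic ring of carbon only gives a 1.5-fold higher number from compound 3 to compound 4 (0.19 log units; within the scatter), a step that stays within the scatter, so this carbon accepts a group of 4 heavy atoms without a clear change in the read-out. Among these compounds, until now, the only step on this ring system was the methoxy change, a 2.2-fold lower number from compound 1 to compound 2 (0.34 log units; beyond the scatter), and the new result shows that the lower number seen there does not carry over to every group placed on this ring system, although the two steps start from different compounds. The data shown hold no measurement that could account for this step.

Going by these compounds, it remains open whether an amine or a carboxylic acid on this same aromatic carbon would give a step beyond the scatter, or would stay as close to compound 3 as trifluoromethyl does. On these data alone, it also remains open whether trifluoromethyl would give a similar step on compound 1, which lacks the fluoro group, and whether methoxy would keep its modest step on compound 3.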